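Swapping the Aryl Amide Group on a Tetrazole Inhibitor

The source may report more compounds than this note shows. Statements on the series, on what has been measured and on what is new or still open speak of the compounds shown alone.

Of the compounds shown here, three have been measured in an assay on microsomes from liver for inhibition of sterol O-acyltransferase 1 (Rattus norvegicus); on this read-out lower numbers stand for stronger inhibition and higher numbers for weaker inhibition. Compound 1 `CCCCCCCCCCCCn1nnc(C(NC(=O)c2ccc(F)cc2F)c2ccccc2)n1` gives 490 nM, and compound 2 `CCCCCCCCCCCCn1nnc(C(NC(=O)c2ccc(C)cc2)c2ccccc2)n1` gives 510 nM; the step of a 1.0-fold higher number from compound 1 to compound 2 (0.02 log units; within the scatter) shows that exchanging one aryl group for another on the carbonyl carbon changed nothing measurable here. Compound 3 `CCCCCCCCCCCCn1nnnc1C(NC(=O)c1c(C)cccc1C)c1ccccc1` gives 180 nM, the lowest number of the three, and its gap to both compound 1 and compound 2 lies beyond the usual scatter, so compound 3 is the strongest inhibitor among those measured.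

Compound 4 `CCCCCCCCCCCCn1nnnc1C(NC(=O)c1ccccc1C(F)(F)F)c1ccccc1` has not yet been measured. It differs from compound 3 in one place: 2-(trifluoromethyl)phenyl in place of 2,6-dimethylphenyl on a carbonyl carbon. For the measured compounds named here, the only measured step, from compound 1 to compound 2, concerns a different pair of aryl groups on a different core, and it was flat; it offers little guidance on this particular exchange. With nothing in the data pointing to a large shift, compound 4 is expected to land close to compound 3, with a modest drift toward a higher number allowed, giving an estimate of 300 nM with a range from 110 nM to 850 nM; the expected step is a 1.7-fold higher number from compound 3 to compound 4 (0.22 log units; within the scatter).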

Compound 4, half-maximal inhibitory concentration: 350 nM
Beside the measured number, compound 4's estimate is 1.2-fold (0.07 log units) below it; measured number inside the range.
By their numbers in this assay, from the lowest: compounds 3, 4, 1 and 2 (each within the scatter of the next, the first and the last beyond it).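

For the compounds shown here, the earlier step on this carbonyl carbon came from a different core, so this is the first exchange read on the core of compound 3. There, 2-(trifluoromethyl)phenyl in place of 2,6-dimethylphenyl gives a 1.9-fold higher number from compound 3 to compound 4 (0.29 log units; within the scatter) in this assay, which means this position accepts the swap without a shift that can be separated from repeat measurements. Nothing available bears on why the result came out this way.

As far as these compounds go, both groups here are substituted phenyl rings, so it remains open whether the same position would accept a non-aromatic group such as cyclohexyl, or a phenyl ring carrying an amine. Also open, from the compounds shown here alone, is whether an unsubstituted phenyl ring on this carbonyl carbon would read the same.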